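The compounds below may be only part of what the source reports. "The series", "measured", "known", "first", "only" and "open" are said of these compounds alone.

Among the compounds with values here, only two compounds with the shared core have numbers so far in a functional assay on U-937 cells (Homo sapiens) for inhibition, read by sulforhodamine B assay, with a stated time of 72 h; a lower number here means a stronger inhibitor of growth, a higher number a weaker inhibitor of growth. Compound 1 `O=C(NO)c1cnc(N2C[C@@H]3CN(S(=O)(=O)c4ccc(OC(F)(F)F)cc4)C[C@@H]3C2)nc1` gives 980 nM, and compound 2 `O=C(NO)c1cnc(N2C[C@H]3CN(C(=O)c4ccc5ccccc5c4)C[C@H]3C2)nc1` gives 390 nM, the lower of the two numbers by a gap beyond the scatter. Compound 3 `O=C(NO)c1cnc(N2C[C@H]3CN(C(=O)CCCOc4ccccc4)C[C@H]3C2)nc1` has not yet been measured. It carries 3-phenoxypropyl in place of naphthalen-2-yl on a carbonyl carbon. Within the data shown here, no measured pair differs in one place only, so the data offer no direct guide to the size of this step. Among the measured compounds shown here, only a small weakening is expected in this assay, possibly not beyond the scatter, since the numbers measured so far lie close together. The expected change is a 1.3-fold higher number from compound 2 to compound 3 (0.12 log units; within the scatter). For compound 3 the estimated value is 520 nM, with an expected range of 170 nM to 1600 nM.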

Compound 3, concentration for 50% growth inhibition: 900 nM
Estimate against measurement, compound 3: 1.7-fold (0.24 log units) below; measured number inside the range.
By their numbers in this assay, from the lowest: compound 2; then compounds 3 and 1 (each within the scatter of the next).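

Within the data shown here, the step gives the first direct reading at this position, on a carbonyl carbon whose other neighbour is an amide-type nitrogen in a ring: in this assay, 3-phenoxypropyl in place of naphthalen-2-yl gives a 2.3-fold higher number from compound 2 to compound 3 (0.36 log units; beyond the scatter), a modest change that lies beyond the scatter. The two groups match in their count of heavy atoms, so this step goes with a change in the kind of group, with one six-membered aromatic ring and a chain oxygen where naphthalen-2-yl has two such rings, and not with a change in the number of heavy atoms. Nothing measured gives a reason for the step.

The compounds shown leave open whether the higher number goes with the loss of the second aromatic ring, the chain, or its oxygen. A 3-phenylpropyl group, which lacks that oxygen, or a shorter chain such as 2-phenoxyethyl, would be needed on the same carbonyl carbon to separate these.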